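This account rests on a few compounds, and the source may have more. Where it says the series, first, only, none or still open, it means among the compounds named here.

Of the compounds shown here, three of a shared core have been measured in a functional assay on SF-268 cells (Homo sapiens) for inhibition, read by sulforhodamine B assay, with a stated time of 48 h; a lower number here means a stronger inhibitor of growth, a higher number a weaker inhibitor of growth. Compound 1 `COc1ccc(-c2cc(/C=C/C(=O)c3ccc(N)cc3)[nH]n2)cc1` gives 1810 nM, compound 2 `COc1cc(-c2cc(/C=C/C(=O)c3ccc(N)cc3)[nH]n2)cc(OC)c1OC` gives 1690 nM, and compound 3 `COc1cc(-c2cc(/C=C/C(=O)c3ccc(F)c(F)c3)[nH]n2)cc(OC)c1OC` gives 3150 nM. Compound 2 holds the lowest of the three numbers, but compound 1 sits within the scatter of it, and even the change a 1.9-fold higher number from compound 2 to compound 3 (0.27 log units; within the scatter) stays within the scatter. Compound 4 `COc1ccc(-c2cc(/C=C/C(=O)c3ccc(N)cc3)[nH]n2)cc1OC` differs from compound 2 by hydrogen in place of methoxy on an aromatic carbon. Going by the values given here, no measured step touches that position; the only related evidence is that compound 1, which carries fewer methoxy groups than compound 2, gives a number within the scatter of compound 2, so no step beyond the scatter is expected in this assay. The estimate for compound 4 is therefore 1750 nM, in a range from 900 nM to 3400 nM. That estimate means a step of a 1.0-fold higher number from compound 2 to compound 4 (0.02 log units; within the scatter) is expected.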

Compound 4, concentration for 50% growth inhibition: 1890 nM
The estimate for compound 4 lay 1.1-fold (0.03 log units) below the measured number, within the range that was stated.
By their numbers in this assay, from the lowest: compounds 2, 1, 4 and 3 (each within the scatter of the next).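

In this assay, going by these compounds alone, hydrogen in place of methoxy, on an aromatic carbon ortho to a methoxy group, gives a 1.1-fold higher number from compound 2 to compound 4 (0.05 log units; within the scatter) and so provides a single-place reading that the earlier compounds, which differ in two places, could not. Methoxy in place of hydrogen gives a 1.0-fold higher number from compound 1 to compound 4 (0.02 log units; within the scatter) and also stays within the scatter. Nothing available explains why these steps are so small. From the compounds shown here alone, whether an amine or a carboxylic acid on this carbon would step beyond the scatter remains open, as does whether hydrogen in place of methoxy reads the same with 3,4-difluorophenyl on the carbonyl carbon.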